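The source may hold more compounds than are shown below. What is called first, only, known or untested is meant among the compounds shown, and "the series" means these compounds.

Measured so far:
- compound 1 `CCOc1cc(NC(=O)C2(NC(=O)c3ccc4c(C5CCCC5)c(-c5ncc(Cl)cn5)n(C)c4c3)CCC2)ccc1/C=C/C(=O)OC(=O)C[C@H](O)C(=O)O`: 5.57 h in an ADME assay (liver) for pharmacokinetics, with Liver microsome (Homo sapiens) as the target, using microsomes; on this read-out lower numbers stand for a shorter-lived compound and higher numbers for a longer-lived compound
- compound 2 `CCOc1cc(NC(=O)C2(NC(=O)c3ccc4c(C5CCCC5)c(-c5ncc(Cl)cn5)n(C)c4c3)CCC2)ccc1/C=C/C(=O)OCOP(=O)(O)OC(C)(C)C`: 1.48 h in this assay

Compound 1 stands highest of the two numbers in this assay; its nearest neighbour is compound 2, and the step of a 3.8-fold lower number from compound 1 to compound 2 (0.58 log units; beyond the scatter) lies beyond the scatter.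

Compound 3 `CCCCCCOC(=O)/C=C/c1ccc(NC(=O)C2(NC(=O)c3ccc4c(C5CCCC5)c(-c5ncc(Cl)cn5)n(C)c4c3)CCC2)cc1OCC` is not yet measured. It differs from compound 1 in one place: hexyl in place of (2-carboxy-2-hydroxyethyl)carbonyl on an oxygen next to a carbonyl group

Among the compounds with values here, the only measured step that touches this position is a 3.8-fold lower number from compound 1 to compound 2 (0.58 log units; beyond the scatter), where a different group also entered in place of (2-carboxy-2-hydroxyethyl)carbonyl on the same oxygen. That step was modest and downward. Within the data shown here, no step with hexyl at this place has been measured, so the bearing of compound 2 on compound 3 is indirect. A downward step of similar or smaller size is expected, though a result within the scatter of compound 1 cannot be ruled out.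

For compound 3 the estimate in this assay is 2.5 h, with a range from 1 h to 6 h, which means an expected step of a 2.2-fold lower number from compound 1 to compound 3 (0.35 log units; beyond the scatter).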

Compound 3, half-life: 17.9 h
For compound 3 the middle estimate is 7.2-fold (0.85 log units) below the measured one; the whole stated range lies below it.
By their numbers in this assay, from the lowest: compound 2; then compound 1; then compound 3.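

Within the data shown here, on the oxygen next to the carbonyl group, the half-life in this assay can move upward as well as downward: hexyl gives a 3.2-fold higher number from compound 1 to compound 3 (0.51 log units; beyond the scatter) in this series, while the only earlier step at this place went down. Changing the group at this place alone, with the rest of the molecule held fixed, is also enough for a large change (a 12-fold higher number from compound 2 to compound 3 (1.08 log units; beyond the scatter)) in the same read-out. Nothing available explains either step.

Going by these compounds, whether the gain belongs to hexyl itself or to carbon-only chains in general remains open, and an ethyl group, an octyl chain or a branched tert-butyl group at this oxygen would separate these readings. On these data alone, it is also open whether a chain carrying an amine or a carboxylic acid would keep the longer half-life seen with hexyl.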